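Hydroxy in Place of Dimethylamino: Compound 1 to Compound 3

This account rests on a few compounds, and the source may have more. Where it says the series, first, only, none or still open, it means among the compounds named here.

Compound 1 `CCOC(=O)c1sc(Nc2nc(N3CCC(O)CC3)cc(N3CCC(N(C)C)CC3)n2)nc1C`: 1500 nM
Compound 2 `CCOC(=O)c1sc(Nc2nc(N3CCC(N(C)C)CC3)cc(N3CCCC(CO)C3)n2)nc1C`: 5000 nM

Among the measured compounds shown here, in a functional assay on PBMC cells (Homo sapiens) for antiproliferative activity, read by thymidine incorporation, with a stated time of 3 days (on this read-out higher numbers stand for weaker inhibition and lower numbers for stronger inhibition), compound 1 gives 1500 nM, the lower of the two numbers so far. Compound 3 `CCOC(=O)c1sc(Nc2nc(N3CCC(O)CC3)cc(N3CCC(O)CC3)n2)nc1C` carries hydroxy in place of dimethylamino on a saturated ring carbon. For the measured compounds named here, no measured step covers this change. The nearest is a 3.3-fold higher number from compound 1 to compound 2 (0.52 log units; beyond the scatter), made at a different group, so it offers only a rough guide to size. A modest move toward weaker inhibition in this assay is therefore expected, though with little certainty. The estimated change is a 2.7-fold higher number from compound 1 to compound 3 (0.43 log units; beyond the scatter). For compound 3 the expected value is 4000 nM, with an estimated range of 1000 nM to 15000 nM.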

Compound 3, half-maximal inhibitory concentration in the PBMC assay: 120 nM
Compound 3: middle estimate off by 33-fold (1.52 log units), on the high side, outside the stated range (below it).
By their numbers in the PBMC assay, from the lowest: compound 3; then compound 1; then compound 2.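

Among the compounds shown here, in the PBMC assay the change from 4-(dimethylamino)piperidin-1-yl to 4-hydroxypiperidin-1-yl gives a 13-fold lower number from compound 1 to compound 3 (1.10 log units; beyond the scatter), so this ring carbon, unchanged between the earlier compounds, moves the read-out in the opposite direction to the step at the other group, a 3.3-fold higher number from compound 1 to compound 2 (0.52 log units; beyond the scatter), and further. In a physicochemical assay for solubility, at pH 6.5 (on this read-out higher numbers stand for higher solubility and lower numbers for lower solubility), compound 1 gives 20 ug/mL and compound 3 gives 20 ug/mL, and the same change gives no change at the digits printed from compound 1 to compound 3 (within the scatter), so the gain in the cell read-out comes with no shift in solubility.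

On these data alone, whether a primary amine, a methoxy or a carboxylic acid on this ring carbon would match hydroxy remains open. The material shown offers nothing that explains the size of this step.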